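This account rests on a few compounds, and the source may have more. Where it says the series, first, only, none or still open, it means among the compounds named here.

In a functional assay on HepG2 cells (Homo sapiens) for inhibition, read by MTT assay, with a stated time of 24 h (a higher number here means a weaker inhibitor, a lower number a stronger inhibitor), the measured compounds are:

Compound 1 `CC1(C)[C@H]2CC[C@]1(C)N(Cc1cn(-c3cccc(F)c3)nn1)C(=O)C2`: 80 nM
Compound 2 `CC1(C)[C@H]2CC[C@]1(C)N(Cc1cn(-c3ccc(F)cc3)nn1)C(=O)C2`: 90 nM
Compound 3 `CC1(C)[C@H]2CC[C@]1(C)N(Cc1cn(-c3ccccc3Cl)nn1)C(=O)C2`: 60 nM

These three share a core and differ only in the aryl group on the triazole-type ring, a five-membered aromatic ring with three nitrogens. Compound 3 stands within the usual scatter of both other compounds, so the numbers set no order among the three.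

The next compound is compound 4 `CC1(C)[C@H]2CC[C@]1(C)N(Cc1cn(-c3cccc(Cl)c3)nn1)C(=O)C2`, not yet measured. It has the same atoms as compound 3, joined differently: 3-chlorophenyl in place of 2-chlorophenyl on an aromatic nitrogen. In words, 3-chlorophenyl sits in place of 2-chlorophenyl on an aromatic nitrogen.

Among the compounds with values here, no measured pair isolates this exact change, since only one chlorine-bearing compound has a value so far. The nearest evidence comes from three aryl swaps. One is a 1.1-fold higher number from compound 1 to compound 2 (0.05 log units; within the scatter), and it exchanges one fluorophenyl for another. The others are a 1.3-fold lower number from compound 1 to compound 3 (0.12 log units; within the scatter) and a 1.5-fold lower number from compound 2 to compound 3 (0.18 log units; within the scatter), and both bring in 2-chlorophenyl. All three steps are small and stay within the scatter, so swapping these aryl groups has not yet moved the number measurably.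

No step beyond the scatter is therefore expected, and the direction is open. The expected step is a 1.2-fold higher number from compound 3 to compound 4 (0.07 log units; within the scatter). The estimate for compound 4 is 70 nM, with an expected range of 35 nM to 140 nM.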

Compound 4, half-maximal inhibitory concentration: 60 nM
Compound 4: middle estimate off by 1.2-fold (0.07 log units), on the high side; low and high end bracket the measured number.
By their numbers in this assay, from the lowest: compounds 3, 4, 1 and 2 (each within the scatter of the next).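

In this assay, within the data shown here, the one pair that isolates the place of the chlorine on the aryl group gives no change at the digits printed from compound 3 to compound 4 (within the scatter), so 3-chlorophenyl and 2-chlorophenyl on the aromatic nitrogen cannot be told apart here. Among these compounds, a clean halogen swap is also available for the first time, chloro in place of fluoro on an aromatic carbon, and it gives a 1.3-fold lower number from compound 1 to compound 4 (0.12 log units; within the scatter), while replacing 4-fluorophenyl with 3-chlorophenyl gives a 1.5-fold lower number from compound 2 to compound 4 (0.18 log units; within the scatter). Among these four compounds, then, neither which of the two halogens is present nor where it sits among the positions tested has moved the number measurably, a statement that reaches no further than these fluorophenyl and chlorophenyl groups.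

Nothing shown gives a reason for this flat result. On these data alone, it remains open whether a plain phenyl with no halogen, 4-chlorophenyl, or a phenyl carrying an amine or a carboxylic acid would stay within the same narrow range, or whether a group of that kind is what it takes to shift the number.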